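A Methyl in Place of Fluoro on Compound 2

The compounds below may be only part of what the source reports. "The series", "measured", "known", "first", "only" and "open" are said of these compounds alone.

Within the data shown here, in a functional assay on CWR22R cells (Homo sapiens) for inhibition (on this read-out lower numbers stand for stronger inhibition and higher numbers for weaker inhibition), only two compounds have numbers so far. Compound 1 (`c1ccc(Nc2cccc(-c3nc4ccccc4s3)c2)nc1`) gives 13000 nM. Compound 2 (`CCn1c(=O)/c(=C2\Sc3ccccc3N2C)s/c1=C\c1ccncc1Nc1ccccc1F`) gives 300 nM, the lower of the two numbers, and the gap between them lies beyond the scatter of repeated measurements. Compound 2 therefore stands as the stronger inhibitor of the pair, although the two values alone cannot show which structural differences matter.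

Compound 3 (`CCn1c(=O)/c(=C2\Sc3ccccc3N2C)s/c1=C\c1ccncc1Nc1ccccc1C`) keeps everything in compound 2 except for one site, with methyl in place of fluoro on an aromatic carbon. The site is on a six-membered aromatic ring of carbon only, ortho to a large group, so the change reads 2-fluorophenyl to 2-methylphenyl. Among the measured compounds shown here, no measured pair shows this exchange, so the expectation starts from compound 2 at 300 nM. A small move toward weaker inhibition is expected, though none beyond the scatter, and the estimated result is a 1.3-fold higher number from compound 2 to compound 3 (0.12 log units; within the scatter). In this assay, compound 3 is expected to give 400 nM, with an estimated range from 130 nM to 1200 nM.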

Compound 3, half-maximal inhibitory concentration: 470 nM
For compound 3 the middle estimate is 1.2-fold (0.07 log units) below the measured one; the range from low to high includes it.
By their numbers in this assay, from the lowest: compounds 2 and 3 (each within the scatter of the next); then compound 1.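

Replacing fluoro with methyl on an aromatic carbon of the six-membered aromatic ring of carbon only, ortho to a large group, gives a 1.6-fold higher number from compound 2 to compound 3 (0.19 log units; within the scatter) in this assay. This single pair therefore shows that 2-fluorophenyl and 2-methylphenyl cannot be told apart on this read-out, so the site accepts either of these two groups, of one heavy atom each, without a step beyond the scatter. No measurement of any property of the two groups accompanies this step, and the data offer no account of why the numbers lie so close.

Going by these compounds, compound 2 gives 300 nM, and it remains open whether other groups at this site, such as methoxy, hydroxyl, an amine or a longer chain like ethyl, would keep the number within the scatter of that value or move it beyond the scatter. Also open, on these data alone, is whether the same exchange of fluoro for methyl would read alike at other carbons of this ring, since one pair cannot establish a pattern for the ring as a whole.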